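A few compounds are considered here, and "the series" means these few. Any claim that something is new, unique, unknown or untested is made for them only; others in the source may bear on it.

In an ADME assay on Caco-2 cells (Homo sapiens) for permeability, read by LC-MS, in the apical to basolateral direction, with a stated time of 60 min, at pH 6.5 (a higher number here means that the compound crosses the layer faster, a lower number that the compound crosses the layer more slowly), three compounds have been measured:
- compound 1 `O=C(NCc1cc(Cl)ccc1-n1cnnn1)[C@@H]1C[C@@H]2C[C@@H]2N1C(=O)[C@H](O)CC1CC1` gives 3.6 10^-6 cm/s
- compound 2 `O=C(NCc1cc(Cl)ccc1-n1cnnn1)[C@@H]1C[C@H]2C[C@H]2N1C(=O)[C@H](O)CC1CC1` gives 6.9 10^-6 cm/s
- compound 3 `CC(C)(C)[C@@H](O)C(=O)N1NCC[C@H]1C(=O)NCc1cc(Cl)ccc1-n1cnnn1` gives 7.2 10^-6 cm/s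

These numbers lie close together. Compound 1 stands within the usual scatter of both compound 2 and compound 3, so the three cannot be ranked.

Compound 4 `CC(C)(C)C[C@@H](O)C(=O)N1[C@H](C(=O)NCc2cc(Cl)ccc2-n2cnnn2)C[C@@H]2C[C@@H]21` has no number yet. It keeps the core of compound 1 and changes one group: tert-butyl in place of cyclopropyl on a saturated chain carbon, two bonds along the chain from a carbonyl carbon and an oxygen on a saturated carbon. Cut one bond further out, the same difference reads cyclopropylmethyl to neopentyl.

For the measured compounds named here, only one measured step exists, a 1.9-fold higher number from compound 1 to compound 2 (0.28 log units; within the scatter), and it reflects (the fact that compounds 1 and 2 differ only in the configuration as drawn). That step leaves the cyclopropyl group untouched, so it bears on the new change only indirectly, as a sign of how little the number moved within this series. Compound 3 does carry a tert-butyl group and gives 7.2 10^-6 cm/s, but its core differs too, so it offers no clean comparison.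

No step beyond the scatter is therefore expected in this assay, although the lean is slightly upward given the value of compound 3. The expected step is a 1.4-fold higher number from compound 1 to compound 4 (0.14 log units; within the scatter). For compound 4 the estimated value is 5 10^-6 cm/s, with an expected range from 2.2 10^-6 cm/s to 11 10^-6 cm/s.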

Compound 4, apparent permeability: 25 10^-6 cm/s
Compound 4: middle estimate off by 5.0-fold (0.70 log units), on the low side; the whole stated range lies below it.
By their numbers in this assay, from the lowest: compounds 1, 2 and 3 (each within the scatter of the next); then compound 4.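

In this assay, replacing cyclopropyl with tert-butyl on a saturated chain carbon, two bonds along the chain from a carbonyl carbon and an oxygen on a saturated carbon, gives a 6.9-fold higher number from compound 1 to compound 4 (0.84 log units; beyond the scatter). For the compounds shown here, this shows that a change of group at this position can move the number beyond the scatter, which the earlier compounds could not show: the only step among them, a 1.9-fold higher number from compound 1 to compound 2 (0.28 log units; within the scatter), lies within the scatter and leaves this group untouched. What is known beyond the numbers concerns only the configuration of compounds 1 and 2, so it offers no explanation for the new step.

This single pair swaps a three-membered carbon ring for an open group with one more carbon, so it cannot separate the loss of the ring from the gain of a carbon; isopropyl, cyclobutyl or a longer chain such as n-butyl at the same place would be needed to pull those apart. It also leaves open whether the same change would give a similar step on the core of compound 2, which differs from compound 1 only in configuration.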